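Swapping the para substituent in a quinoline cinnamamide series

This account rests on a few compounds, and the source may have more. Where it says the series, first, only, none or still open, it means among the compounds named here.

Compound 1 `CCCc1cc(N)c2cc(NC(=O)/C=C/c3ccc(N)cc3)ccc2n1` is the weakest of three compounds examined in an assay on isolated protein for displacement of a labelled ligand from melanin-concentrating hormone receptor 1 (Homo sapiens); on this read-out lower numbers stand for stronger inhibition and higher numbers for weaker inhibition; in this assay compound 1 gives 190 nM. Compound 3 `CCCc1cc(NC2CCC2)c2cc(NC(=O)/C=C/c3ccc(C(F)(F)F)cc3)ccc2n1` gives 18 nM, and compound 2 `Nc1cc(C2CCCC2)nc2ccc(NC(=O)/C=C/c3ccc(C(F)(F)F)cc3)cc12` gives 0.8 nM. Both of those stronger binders carry a trifluoromethyl group on the phenyl ring where compound 1 carries an amino group, but they also differ from compound 1 elsewhere on the shared core, so no single change can be read off from them.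

Compound 4 `CCCc1cc(N)c2cc(NC(=O)/C=C/c3ccc(C(C)C)cc3)ccc2n1` differs from compound 1 in one place only: isopropyl in place of amino on an aromatic carbon. For the measured compounds named here, no measured pair shows this exact change. The expectation is that the step from compound 1 to compound 4 in this assay lowers the number clearly beyond the scatter, by a 9.5-fold lower number from compound 1 to compound 4 (0.98 log units; beyond the scatter), because compound 2 gives 0.8 nM and compound 3 gives 18 nM while both lack the amino group on that phenyl ring, and both sit far below compound 1. For compound 4 the estimated value is 20 nM, with a range from 4 nM to 90 nM.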

Compound 4, half-maximal inhibitory concentration: 2.9 nM
Beside the measured number, compound 4's estimate is 6.9-fold (0.84 log units) above it; measured number below the stated range.
By their numbers in this assay, from the lowest: compound 2; then compound 4; then compound 3; then compound 1.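

With the shared core held fixed, this pair isolates the group on the phenyl ring, which compounds 2 and 3 could not do because they also differ from compound 1 elsewhere. In this assay, the change from 4-aminophenyl to 4-isopropylphenyl gives a 66-fold lower number from compound 1 to compound 4 (1.82 log units; beyond the scatter), so this one position alone can shift the read-out by a large margin. The amino group, with its hydrogen-bond donor and acceptor, is clearly not required for strong inhibition here, although no measurement shown explains why the isopropyl group does so much better.

The compounds shown leave open how a methyl, tert-butyl or methoxy group at this position would compare on the same core. A single pair also cannot show whether the gain comes from adding isopropyl, removing amino or both.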